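From Acetyl to Sulfamoyl on the Shared Core

The source may report more compounds than this note shows. Statements on the series, on what has been measured and on what is new or still open speak of the compounds shown alone.

In a functional assay on Ehrlich cells (Mus musculus) for inhibition (on this read-out lower numbers stand for stronger inhibition and higher numbers for weaker inhibition), three compounds built on one core have been measured. Compound 1 `O=C(O)c1ccc2c(O)c(C(=O)O)cnc2c1`, which carries a carboxy group, gives 5750000 nM. Compound 2 `CN(C)c1ccc2c(O)c(C(=O)O)cnc2c1`, with dimethylamino at that place, gives 468000 nM. Compound 3 `CC(=O)c1ccc2c(O)c(C(=O)O)cnc2c1`, with acetyl there, gives 794000 nM. Compound 3 therefore stands well under the carboxy compound, with a 7.2-fold lower number from compound 1 to compound 3 (0.86 log units; beyond the scatter). It cannot be told apart from the dimethylamino compound, with a 1.7-fold higher number from compound 2 to compound 3 (0.23 log units; within the scatter).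

The next compound is compound 4 `NS(=O)(=O)c1ccc2c(O)c(C(=O)O)cnc2c1`, which has sulfamoyl in place of acetyl on an aromatic carbon. Within the data shown here, no measured step involves sulfamoyl, so the evidence is indirect. Leaving carboxy gave clear drops, a 12-fold lower number from compound 1 to compound 2 (1.09 log units; beyond the scatter) alongside the acetyl step already given, whereas exchanging dimethylamino for acetyl stayed within the scatter. Among the measured compounds shown here, with only three compounds, this is a thin basis, and the carboxy compound is the only one that stands apart. A swap of one non-carboxy group for another is therefore expected to produce no change beyond the scatter in this assay, though a small rise would not be surprising. The expected step is a 1.3-fold higher number from compound 3 to compound 4 (0.10 log units; within the scatter). For compound 4, the estimated value is 1000000 nM, within an expected range of 350000 nM to 3000000 nM.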

Compound 4, half-maximal inhibitory concentration: 3390000 nM
Compound 4: the middle estimate sits 3.4-fold (0.53 log units) below what was measured; the measured number lies above the stated range.
By their numbers in this assay, from the lowest: compounds 2 and 3 (each within the scatter of the next); then compounds 4 and 1 (each within the scatter of the next).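

In this assay, the groups other than carboxy at this aromatic carbon prove not to be interchangeable: sulfamoyl in place of acetyl gives a 4.3-fold higher number from compound 3 to compound 4 (0.63 log units; beyond the scatter), and sulfamoyl in place of dimethylamino gives a 7.2-fold higher number from compound 2 to compound 4 (0.86 log units; beyond the scatter). Set against carboxy, the same group gives a 1.7-fold lower number from compound 1 to compound 4 (0.23 log units; within the scatter), so compound 1 no longer stands apart, and the four compounds fall into two pairs, with compounds 2 and 3 holding the lower numbers and compounds 1 and 4 the higher ones. No measurement is available that explains why sulfamoyl falls with carboxy and not with acetyl or dimethylamino.

The compounds shown leave open whether the hydrogen-bond donor that sulfamoyl brings and acetyl lacks has any bearing on the step, a question that a dimethylsulfamoyl or methylsulfonyl group at this place could address. They also leave open where a primary amide or a nitrile would fall relative to the two pairs, and whether a simple amine would stay with the lower pair.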